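Pyrrol-2-yl hydrazone arm on the thiosemicarbazide core

The source may hold more compounds than are shown below. What is called first, only, known or untested is meant among the compounds shown, and "the series" means these compounds.

Compound 1 `CC1=CC[C@H](C(C)(C)NC(=S)NN)CC1` is the bare thiosemicarbazide of the series. In a functional assay on NCI-H460 cells (Homo sapiens) for inhibition, read by sulforhodamine B assay, with a stated time of 48 h (a higher number here means a weaker inhibitor of growth, a lower number a stronger inhibitor of growth), compound 1 gives 42000 nM, the highest number of the three measured; its nearest neighbour is compound 3 `CC1=CC[C@H](C(C)(C)NC(=S)N/N=C/c2ccco2)CC1`, which gives 13500 nM, and the furthest is compound 2 `CC1=CC[C@H](C(C)(C)NC(=S)N/N=C/c2ccccc2O)CC1`, which gives 1900 nM.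

Compound 4 `CC1=CC[C@H](C(C)(C)NC(=S)N/N=C/c2ccc[nH]2)CC1` differs from compound 1 by a group of 7 heavy atoms (5 carbon, 2 nitrogen; one five-membered aromatic ring with 1 hetero atom) in place of one nitrogen atom, on an amide-type nitrogen. Going by the values given here, two measured steps bear on this change. The step of a 3.1-fold lower number from compound 1 to compound 3 (0.49 log units; beyond the scatter) shows the effect of attaching a five-membered aromatic hydrazone arm to the core. The step of a 7.1-fold higher number from compound 2 to compound 3 (0.85 log units; beyond the scatter) shows the span between two different arms on the same core. Compound 4 carries a ring of the same size as compound 3, but with one hydrogen-bond donor in the entering group, a feature that compound 2 also brings with its 2-hydroxyphenyl group.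

A lower number than compound 1 is therefore expected, beyond the scatter, and most likely between the numbers of compound 3 and compound 2. The expected step is a 5.3-fold lower number from compound 1 to compound 4 (0.72 log units; beyond the scatter). Compound 4 is estimated at 8000 nM, with a range from 2500 nM to 25000 nM.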

Compound 4, concentration for 50% growth inhibition: 18000 nM
Estimate against measurement, compound 4: 2.3-fold (0.35 log units) below; measured number inside the range.
By their numbers in this assay, from the lowest: compound 2; then compounds 3 and 4 (each within the scatter of the next); then compound 1.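

Replacing the amino group of compound 1 with the 1H-pyrrol-2-yl hydrazone arm gives a 2.3-fold lower number from compound 1 to compound 4 (0.37 log units; beyond the scatter), so a second five-membered aromatic arm on this amide-type nitrogen also lowers the number beyond the scatter, as the furan-2-yl arm of compound 3 did. Exchanging furan-2-yl for 1H-pyrrol-2-yl on the carbon with a double bond to nitrogen gives a 1.3-fold higher number from compound 3 to compound 4 (0.12 log units; within the scatter), so this assay does not tell these two arms apart. The hydrogen-bond donor of the entering group does not bring compound 4 to the level of compound 2, as a 9.5-fold higher number from compound 2 to compound 4 (0.98 log units; beyond the scatter) remains, which makes compound 4 the case against linking a donor on the arm with the lowest number in this short series.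

From the compounds shown here alone, whether the advantage of compound 2 rests on the hydroxyl or on the phenyl ring stays open, and a plain phenyl arm or a 2-methoxyphenyl arm on the shared core would separate the two. No independent measurement is available to explain any of these steps.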